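The source may report more compounds than this note shows. Statements on the series, on what has been measured and on what is new or still open speak of the compounds shown alone.

Compound 1 `Cn1c(Cc2nn(CCC3OCCO3)c(=O)c3ccccc23)nnc1SCC(=O)Nc1ccc(Cl)cc1Cl` — in an assay on 32D cells for inhibition of interleukin-15 (Mus musculus), read by resazurin assay, with stated times of 30 min and 2.5 days, in the presence of a further agent that is not named here (a lower number here means a stronger inhibitor, a higher number a weaker inhibitor), compound 1 gives > 30000 nM, which is a limit of the assay rather than a number.
Compound 2 `Cn1c(Cc2nn(CCCO)c(=O)c3ccccc23)nnc1SCC(=O)Nc1ccc(Cl)cc1Cl` — in this assay compound 2 gives > 30000 nM, again a limit of the assay and not a number.

The two measured compounds share one core and differ only at the end of the chain on an aromatic nitrogen. The step between them, a step that the two limits leave unreadable from compound 1 to compound 2, cannot be sized, since both ends of it are limits. Compound 2 therefore stands nowhere definite on the numbers shown: its own value is a limit, and the one further value is a limit as well, as the limit of > 30000 nM in this assay, at which 2 of the 2 values shown sit, records.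

Compound 3 `CN(C)CCCn1nc(Cc2nnc(SCC(=O)Nc3ccc(Cl)cc3Cl)n2C)c2ccccc2c1=O` differs from compound 2 by dimethylamino in place of hydroxy on a saturated chain carbon, three bonds along the chain from an aromatic nitrogen. Within the data shown here, the only measured step touches the same chain but was unreadable, so it gives no direction and no size to expect here. The step from compound 2 to compound 3 is accordingly expected to be a step that the limit leaves unreadable from compound 2 to compound 3, which is itself unreadable against a limit. Compound 3 is estimated at 40000 nM, within 5000 nM to 150000 nM, most likely reported again as a limit.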

Compound 3, half-maximal inhibitory concentration: 18800 nM
Estimate against measurement, compound 3: 2.1-fold (0.33 log units) above; low and high end bracket the measured number.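

Among these compounds, with dimethylamino at the end of this chain, compound 3 gives 18800 nM in this assay, the first reading that is a number rather than a limit of the assay. Against the hydroxy end group this is an at least 1.5-fold lower number from compound 2 to compound 3 (0.20 log units; that floor lies within the scatter), and against the 1,3-dioxolan-2-yl end group it is an at least 1.5-fold lower number from compound 1 to compound 3 (0.20 log units; that floor lies within the scatter); both figures are only floors, so the true steps may be larger, but as printed they do not establish a difference beyond the scatter. Even so, this chain end now shows a change that can bring a reading onto the scale, where the earlier compounds had shown only one result: the limit of > 30000 nM in this assay, at which 2 of the 3 values shown sit.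

The compounds shown leave open whether dimethylamino itself matters or whether a primary amine, a piperidine or a carboxylic acid at the same chain end, or dimethylamino on a longer chain, would read the same or differently. On these data alone, the true size of the step from the hydroxy end group also stays unknown, as compound 2 has no number to measure it from.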